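The source may report more compounds than this note shows. Statements on the series, on what has been measured and on what is new or still open speak of the compounds shown alone.

Among the compounds with values here, compound 3 `O/N=C(/CCN1CCN(c2ccccn2)CC1)c1ccccc1Cl` gives 25 nM in a functional assay on HEK293 cells with D(4) dopamine receptor (Homo sapiens) as the target, read by FLIPR (on this read-out lower numbers stand for an effect already at smaller amounts and higher numbers for an effect only at larger amounts of compound), the highest of the three numbers measured so far. Compound 1 `O/N=C(\CCN1CCN(c2ccccn2)CC1)c1ccccc1` gives 4.4 nM and compound 2 `O/N=C(\CCN1CCN(c2ccccn2)CC1)c1ccccc1Cl` gives 24 nM. Two steps are measured: a 5.5-fold higher number from compound 1 to compound 2 (0.74 log units; beyond the scatter) and a 1.0-fold higher number from compound 2 to compound 3 (0.02 log units; within the scatter); the second is flat because of the fact that compounds 2 and 3 differ only in the configuration as drawn. The change to compound 4 `O/N=C(/CCN1CCN(c2ccccn2)CC1)c1cc(F)cc(F)c1` is 3,5-difluorophenyl in place of 2-chlorophenyl on a carbon with a double bond to nitrogen. Neither measured step covers a fluorinated ring; the chloro step shows that an aromatic halogen can move the number, while the configuration step shows that a drawn change alone need not. Compound 4 is expected to give 15 nM, with a range of 3 nM to 80 nM. The expected step is a 1.7-fold lower number from compound 3 to compound 4 (0.22 log units; within the scatter), not beyond the scatter.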

Compound 4, half-maximal effective concentration: 17.5 nM
The estimate for compound 4 lay 1.2-fold (0.07 log units) below the measured number; the range from low to high includes it.
By their numbers in this assay, from the lowest: compound 1; then compounds 4, 2 and 3 (each within the scatter of the next).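

On the carbon with a double bond to nitrogen, 3,5-difluorophenyl can stand in place of 2-chlorophenyl in this assay with no change beyond the scatter: a 1.4-fold lower number from compound 3 to compound 4 (0.15 log units; within the scatter). The chlorine is therefore not required at this position for a number of this size, at least with the configuration drawn for compound 3. Nothing at hand gives a cause for this step.

On these data alone, the swap alters the halogen and its place on the ring together, so the contribution of each stays open. Also open, as far as these compounds go, are 3,5-difluorophenyl in the configuration of compound 2 and a methoxy or trifluoromethyl group on the ring.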